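The source may hold more compounds than are shown below. What is called first, only, known or untested is meant among the compounds shown, and "the series" means these compounds.

Working notes on the series. In a functional assay on PC-3 cells (Homo sapiens) for cytotoxicity, read by resazurin assay, with a stated time of 48 h (on this read-out higher numbers stand for weaker inhibition and lower numbers for stronger inhibition), compound 1 (`C=C(C)[C@@H]1CC=C(CN(OC)C2O[C@H](CO)[C@@H](N=[N+]=[N-])[C@H](O)[C@H]2O)CC1`) gives 22000 nM, compound 2 (`C=C(C)[C@@H]1CC=C(CN(OC)C2O[C@H](CN=[N+]=[N-])[C@@H](N=[N+]=[N-])[C@H](O)[C@H]2O)CC1`) gives 57000 nM and compound 3 (`C=C(C)[C@@H]1CC=C(CN(OC)C2OC[C@@H](O)[C@H](O)[C@H]2O)CC1`) gives 152000 nM. Compound 3 therefore has the highest number of the three, and its gaps to both others lie beyond the scatter.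

The next entry is compound 4 (`C=C(C)[C@@H]1CC=C(CN(OC)C2OC[C@@H](N=[N+]=[N-])[C@H](O)[C@H]2O)CC1`), which differs from compound 3 as follows: azido in place of hydroxy on a saturated ring carbon. In short, this is azido in place of hydroxy on a saturated ring carbon.

For the measured compounds named here, only one measured step involves this swap: a 2.6-fold higher number from compound 1 to compound 2 (0.41 log units; beyond the scatter). That step is modest and points upward, but it occurs on a saturated chain carbon bound to a saturated ring carbon, not on a ring carbon, so it is only a loose guide. The other evidence points the opposite way. Compound 1 at 22000 nM and compound 2 at 57000 nM both carry azido on a saturated ring carbon and both lie under compound 3, although they also differ from it elsewhere.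

A moderate fall in this assay is therefore expected, and the estimated change is a 2.5-fold lower number from compound 3 to compound 4 (0.40 log units; beyond the scatter). The expected value for compound 4 is 60000 nM, with an estimated range of 20000 nM to 150000 nM.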

Compound 4, half-maximal inhibitory concentration: 170000 nM
Beside the measured number, compound 4's estimate is 2.8-fold (0.45 log units) below it, outside the stated range (above it).
By their numbers in this assay, from the lowest: compound 1; then compound 2; then compounds 3 and 4 (each within the scatter of the next).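

On this saturated ring carbon, azido in place of hydroxy makes no readable difference in this assay: the swap gives a 1.1-fold higher number from compound 3 to compound 4 (0.05 log units; within the scatter) and stands apart from the only earlier case of the same swap, on a saturated chain carbon, which gave a 2.6-fold higher number from compound 1 to compound 2 (0.41 log units; beyond the scatter). With azido held on the ring carbon, the separation from the two lower numbers comes from the large change at another saturated ring carbon: hydrogen in place of azidomethyl gives a 3.0-fold higher number from compound 2 to compound 4 (0.47 log units; beyond the scatter) and hydrogen in place of hydroxymethyl gives a 7.7-fold higher number from compound 1 to compound 4 (0.89 log units; beyond the scatter), both beyond the scatter. No accompanying measurement bears on these steps, so the series offers no explanation for them.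

The compounds shown leave open what an amine or a carboxylic acid would give on the ring carbon that carries azido in compound 4. They also leave open whether azido in place of hydroxy on that ring carbon would stay as flat on a core that keeps the hydroxymethyl group of compound 1, where only the azido form appears here.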